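Acyl variation on the aromatic oxygen

The compounds below may be only part of what the source reports. "The series", "measured", "known", "first", "only" and "open" are said of these compounds alone.

Measured compounds:
compound 1 `C#CCOc1cc(/C=C/C(=O)c2ccc(OC)c3c2OC(C)(C)C=C3)ccc1OC`: > 10000 nM
compound 2 `CCC(=O)Oc1cc(/C=C/C(=O)c2ccc(OC)c3c2OC(C)(C)C=C3)ccc1OC`: 90 nM

Going by the values given here, in a functional assay on HepG2 cells (Homo sapiens) for cytotoxicity, read by MTT assay (on this read-out higher numbers stand for weaker inhibition and lower numbers for stronger inhibition), compound 2 gives 90 nM, the only number so far. For compound 1 the figure is the limit of > 10000 nM in this assay, at which 1 of the 2 values shown sits, a limit of the assay and not a number. Among the compounds with values here, the one step in hand, an at least 110-fold lower number from compound 1 to compound 2 (2.04 log units; beyond the scatter), swaps the group sitting directly on the aromatic oxygen. Compound 3 `COc1ccc(/C=C/C(=O)c2ccc(OC)c3c2OC(C)(C)C=C3)cc1OC(=O)c1ccco1` differs from compound 2 by furan-2-yl in place of ethyl on a carbonyl carbon; the ester itself is kept, and only the group on its carbonyl carbon changes, from propanoyl to (furan-2-yl)carbonyl. Within the data shown here, no measured step varies this part of the molecule, so the step in hand does not bear directly on the change from compound 2 to compound 3. The ester that gave compound 2 its number is retained, so the step of a 1.7-fold higher number from compound 2 to compound 3 (0.22 log units; within the scatter) is expected to stay within the scatter or be modest, with no clear direction. Compound 3 is therefore estimated at 150 nM in this assay, in the range 40 nM to 600 nM.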

Compound 3, half-maximal inhibitory concentration: 370 nM
Estimate against measurement, compound 3: 2.5-fold (0.39 log units) below, within the range that was stated.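

In this assay the group on the carbonyl carbon of the ester does change the number, with a 4.1-fold higher number from compound 2 to compound 3 (0.61 log units; beyond the scatter), and the earlier step, which swapped the whole group on the aromatic oxygen, could not show this. Furan-2-yl in place of ethyl therefore gives a modest loss, while the propargyl compound remains far weaker than this second ester, with an at least 27-fold lower number from compound 1 to compound 3 (1.43 log units; beyond the scatter), so the low numbers now rest on two acyl groups and not on compound 2 alone. For compound 1 the figure is a limit of the assay and not a number: the limit of > 10000 nM in this assay, at which 1 of the 3 values shown sits.

With only propanoyl and (furan-2-yl)carbonyl on this oxygen, the data cannot separate the effect of the ring from that of the larger group, and benzoyl, acetyl or a longer chain such as butanoyl would help to divide them. Also open, as far as these compounds go, is whether the ester linkage itself is needed on this oxygen, as a carbamate or a plain methyl ether in its place would test.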